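This account rests on a few compounds, and the source may have more. Where it says the series, first, only, none or still open, it means among the compounds named here.

Measured so far:
Compound 1 `CC1(c2ccc(F)cc2)NC(=O)N(CC(O)CN2CCN(c3ccccc3)CC2)C1=O` gives 223 nM in an assay on HEK293 cells for displacement of a labelled ligand from 5-hydroxytryptamine receptor 7 (Homo sapiens); on this read-out higher numbers stand for weaker inhibition and lower numbers for stronger inhibition.
Compound 2 `CCOc1ccccc1N1CCN(CC(O)CN2C(=O)NC(C)(c3ccc(F)cc3)C2=O)CC1` gives 10 nM in this assay.

Among the compounds with values here, of the two numbers known in this assay, compound 1 has the higher one, so it is the weaker binder of the pair. Within the data shown here, the only step measured so far, a 22-fold lower number from compound 1 to compound 2 (1.35 log units; beyond the scatter), comes from one change: ethoxy in place of hydrogen on an aromatic carbon of the outer phenyl ring.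

Compound 3 `CC1(c2ccc(F)cc2)NC(=O)N(CC(O)CN2CCN(c3ccccc3C#N)CC2)C1=O` is not yet measured. It differs from compound 1 by cyano in place of hydrogen on an aromatic carbon. The new group sits at the same place on the ring that the ethoxy occupies in compound 2, but it is a different group, so the measured step tells only that filling this position once paid off strongly. No case shows what a cyano group does there.

Given this, the expectation for compound 3 is a lower number than compound 1 in this assay, but a smaller gain than the ethoxy brought, with wide uncertainty. The step expected is a 3.7-fold lower number from compound 1 to compound 3 (0.57 log units; beyond the scatter). The estimate for compound 3 is 60 nM, with a range from 15 nM to 250 nM.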

Compound 3, inhibition constant: 14 nM
For compound 3 the middle estimate is 4.3-fold (0.63 log units) above the measured one; the measured number lies below the stated range.
By their numbers in this assay, from the lowest: compounds 2 and 3 (each within the scatter of the next); then compound 1.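

In this assay the gain at this place on the ring is not tied to the ethoxy group: cyano in place of hydrogen also gives a large step, a 16-fold lower number from compound 1 to compound 3 (1.20 log units; beyond the scatter), on the same core. Exchanging the two groups directly gives a 1.4-fold higher number from compound 2 to compound 3 (0.15 log units; within the scatter), so on this read-out the ethoxy and the cyano compounds cannot be told apart, even though the groups themselves are very different in name and shape on paper. This shows that a second, unrelated group can do what the first did here, although no measurement available explains why either one helps.

Only hydrogen, ethoxy and cyano are shown at this place, so it remains open whether a methyl group, a chlorine atom, an amine or a carboxylic acid would give a similar step, or whether the gain would shrink or vanish with some of them. From the compounds shown here alone, it is also open whether cyano would give the same step at another place on the ring, or on a compound whose core carries a change elsewhere.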